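This account rests on a few compounds, and the source may have more. Where it says the series, first, only, none or still open, it means among the compounds named here.

Compound 1 `COc1cc(-c2nnc3n2NC(c2ccco2)C(C(=O)c2cccc4ccccc24)S3)cc(OC)c1OC` gives in a functional assay on PC-3 cells (Homo sapiens) for cytotoxicity, read by MTT assay, with a stated time of 48 h (on this read-out higher numbers stand for weaker inhibition and lower numbers for stronger inhibition), the value > 100000 nM, which is a limit of the assay and not a number.
Compound 2 `COc1ccc(C(=O)C2Sc3nnc(-c4cc(OC)c(OC)c(OC)c4)n3NC2c2ccco2)cc1` gives in this assay the value > 100000 nM, again a limit.
Compound 3 `COc1cc(-c2nnc3n2NC(c2ccco2)C(C(=O)c2ccc(F)c(F)c2)S3)cc(OC)c1OC` gives in this assay the value 36000 nM.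

Within the data shown here, compound 3 thus holds the only real number of the three; the other two sit at the limit (the limit of > 100000 nM in this assay, at which 2 of the 3 values shown sit). The step that the two limits leave unreadable from compound 1 to compound 2 cannot be read. The steps of an at least 2.7-fold lower number from compound 1 to compound 3 (0.44 log units; beyond the scatter) and an at least 2.7-fold lower number from compound 2 to compound 3 (0.44 log units; beyond the scatter) both point toward the 3,4-difluorophenyl group.

Compound 4 `COc1cc(-c2nnc3n2NC(c2ccco2)C(C(=O)c2ccc(O)cc2)S3)cc(OC)c1OC` differs from compound 3 by 4-hydroxyphenyl in place of 3,4-difluorophenyl on a carbonyl carbon. Compound 2 shows that a 4-methoxyphenyl group at this carbonyl reaches only the limit, and a 4-hydroxyphenyl group is its close relative, so compound 4 is expected to lose ground in the step of a 2.5-fold higher number from compound 3 to compound 4 (0.40 log units; beyond the scatter). Compound 4 is estimated at 90000 nM, between 25000 nM and 300000 nM.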

Compound 4, half-maximal inhibitory concentration: 38300 nM
The estimate for compound 4 lay 2.3-fold (0.37 log units) above the measured number, within the range that was stated.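

The step of a 1.1-fold higher number from compound 3 to compound 4 (0.03 log units; within the scatter) shows that 4-hydroxyphenyl on this carbonyl carbon matches 3,4-difluorophenyl, so a real number here does not depend on fluorine. Hydrogen in place of methyl on the oxygen gives an at least 2.6-fold lower number from compound 2 to compound 4 (0.41 log units; beyond the scatter), and 4-hydroxyphenyl in place of naphthalen-1-yl gives an at least 2.6-fold lower number from compound 1 to compound 4 (0.41 log units; beyond the scatter). Both steps give only a minimum size, because they start from a limit: the limit of > 100000 nM in this assay, at which 2 of the 4 values shown sit.

Going by these compounds, it remains open how a 4-aminophenyl or 4-carboxyphenyl group on this carbonyl carbon would compare. On these data alone, it also remains open whether any group there would give a much lower number than compound 3 and compound 4 do.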